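The compounds below may be only part of what the source reports. "The series", "measured", "known", "first", "only" and "open" are said of these compounds alone.

For the measured compounds named here, only two compounds have numbers so far in a functional assay on HepG2 cells (Homo sapiens) for inhibition, read by MTT assay, with a stated time of 48 h; on this read-out higher numbers stand for weaker inhibition and lower numbers for stronger inhibition. In this assay, compound 1 `COc1ccc(-c2nc3c(c(-c4ccccc4)nn3-c3ccccc3)c(-c3ccc(N4CCCCC4)cc3)c2C#N)cc1` gives 12500 nM, while compound 2 `c1ccc(-c2nn(-c3ccccc3)c3nccc(-c4cccs4)c23)cc1` gives 39300 nM. Compound 2 thus has the higher of the two numbers, and its gap to compound 1 lies beyond the scatter. Compound 3 `c1ccc(-c2ccnc3c2c(-c2ccccc2)nn3-c2ccccc2)cc1` departs from compound 2 in one place, with phenyl in place of thiophen-2-yl on an aromatic carbon, opposite the ring nitrogen (phenyl in place of thiophen-2-yl on an aromatic carbon). Going by the values given here, no measured pair shows a change of this kind, so the data offer no direct guide to its size. The expectation in this assay is therefore a small step in either direction, none beyond the scatter. The expected step is a 1.1-fold lower number from compound 2 to compound 3 (0.05 log units; within the scatter). For compound 3 the estimated value is 35000 nM, with an expected range from 15000 nM to 80000 nM.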

Compound 3, half-maximal inhibitory concentration: 3210 nM
For compound 3 the middle estimate is 11-fold (1.04 log units) above the measured one; the measured number lies below the stated range.
By their numbers in this assay, from the lowest: compound 3; then compound 1; then compound 2.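

In this assay, for the compounds shown here, placing phenyl instead of thiophen-2-yl on the aromatic carbon opposite the ring nitrogen gives a 12-fold lower number from compound 2 to compound 3 (1.09 log units; beyond the scatter) and this is the first single-place step. Going by these compounds alone, it shows that the read-out at this position depends on which aromatic ring is attached, even though the exchange involves only two uncharged aromatic rings. No measurement available here bears on the reason for this step.

This single pair cannot show whether the trend would extend to other groups at this place, such as furan-2-yl, pyridin-3-yl or a morpholine ring. It also leaves open whether the same exchange would have a similar effect on the more heavily substituted core of compound 1.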